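Hydroxy to methoxy on the aromatic ring: notes

A few compounds are considered here, and "the series" means these few. Any claim that something is new, unique, unknown or untested is made for them only; others in the source may bear on it.

Values in a functional assay on P388 cells (Mus musculus) for cytotoxicity; on this read-out higher numbers stand for weaker inhibition and lower numbers for stronger inhibition:
- compound 1 `COc1ccc(C[C@H]2C(=O)N[C@@H](C)C(=O)N(C)[C@H]3Cc4ccc(cc4)Oc4cc(ccc4OC)C[C@@H](C(=O)N[C@H](C)C(=O)N[C@@H](CCO)C(=O)N2C)N(C)C3=O)cc1` gives 60.3 nM
- compound 2 `C[C@@H]1NC(=O)[C@@H](C)NC(=O)[C@@H]2Cc3cccc(c3)Oc3ccc(cc3)C[C@@H](C(=O)N2C)N(C)C(=O)[C@H](C)NC(=O)[C@H](Cc2ccccc2)N(C)C1=O` gives 525 nM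
- compound 3 `C[C@@H]1NC(=O)[C@@H](C)NC(=O)[C@@H]2Cc3ccc(O)c(c3)Oc3ccc(cc3)C[C@@H](C(=O)N2C)N(C)C(=O)[C@H](C)NC(=O)[C@H](Cc2ccccc2)N(C)C1=O` gives 42.7 nM

Compound 3 and compound 1 lie within the scatter of each other at the low end of the three numbers, and compound 2 stands clearly higher. Compound 4 `COc1ccc2cc1Oc1ccc(cc1)C[C@H]1C(=O)N(C)[C@@H](C2)C(=O)N[C@H](C)C(=O)N[C@@H](C)C(=O)N(C)[C@@H](Cc2ccccc2)C(=O)N[C@@H](C)C(=O)N1C` differs from compound 3 in one place: methyl in place of hydrogen on an oxygen on an aromatic ring, which reads as hydroxy to methoxy. For the measured compounds named here, one measured step bears on this hydroxy: a 12-fold lower number from compound 2 to compound 3 (1.09 log units; beyond the scatter), a large step with hydroxy in place of hydrogen on an aromatic carbon. Going by the values given here, no measured pair shows what methyl on that oxygen does, so the size of that step cannot be carried over directly. The oxygen remains in compound 4, so a return to the level of compound 2 at 525 nM is not expected. In this assay, the expected outcome is a 1.6-fold higher number from compound 3 to compound 4 (0.21 log units; within the scatter), a shift toward a higher number that stays within the scatter. Compound 4 is estimated at 70 nM, with an expected range of 25 nM to 250 nM.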

Compound 4, half-maximal inhibitory concentration: 295 nM
Compound 4: middle estimate off by 4.2-fold (0.62 log units), on the low side; the measured number lies above the stated range.
By their numbers in this assay, from the lowest: compounds 3 and 1 (each within the scatter of the next); then compounds 4 and 2 (each within the scatter of the next).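

Methyl on the oxygen on the aromatic ring is not a silent change in this assay: the step, a 6.9-fold higher number from compound 3 to compound 4 (0.84 log units; beyond the scatter), is beyond the scatter and takes back most of what the hydroxy gave. Set against hydrogen on the same aromatic carbon, methoxy gives a 1.8-fold lower number from compound 2 to compound 4 (0.25 log units; within the scatter), so in this pair the lower number goes with hydroxy and does not persist once the oxygen carries methyl. No measurement available here explains the difference between hydroxy and methoxy at this position.

Open, as far as these compounds go, is how other groups would read at this place, such as an amine or a carboxylic acid in place of the hydroxy, or ethyl or a longer chain on the oxygen. Also open, from the compounds shown here alone, is whether methyl on this oxygen has a similar effect on the core of compound 1.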